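The source may report more compounds than this note shows. Statements on the series, on what has been measured and on what is new or still open speak of the compounds shown alone.

In a functional assay on RPMI-8226 cells (Homo sapiens) for cytotoxicity, read by fluorescence, with a stated time of 72 h (on this read-out lower numbers stand for stronger inhibition and higher numbers for weaker inhibition), compound 2 `Nc1n[nH]c(N)c1/N=N/c1ccc(O)cc1`, with hydrogen on the aromatic nitrogen, gives 24900 nM. Compound 3 `Nc1nn(C(=O)c2cccs2)c(N)c1/N=N/c1ccc(O)cc1`, with (thiophen-2-yl)carbonyl there, gives > 100000 nM, which is a limit of the assay. Compound 1 `Nc1nn(C(=O)c2ccc([N+](=O)[O-])cc2)c(N)c1/N=N/c1ccc(O)cc1` gives > 100000 nM, also a limit. Among the compounds with values here, two measured steps bear on the next change: an at least 4.0-fold higher number from compound 2 to compound 3 (0.60 log units; beyond the scatter), and a step that the two limits leave unreadable from compound 1 to compound 3. Compound 4 `CC(=O)n1nc(N)c(/N=N/c2ccc(O)cc2)c1N` differs from compound 3 by methyl in place of thiophen-2-yl on a carbonyl carbon, that is, (thiophen-2-yl)carbonyl to acetyl. Compound 4 keeps a carbonyl on the aromatic nitrogen, so it is expected to remain weak in this assay, though probably not as far out as the limit of > 100000 nM in this assay, at which 2 of the 3 values shown sit. The expected change is modest and towards a lower number: an at least 1.6-fold lower number from compound 3 to compound 4 (0.22 log units; that floor lies within the scatter). For compound 4 the estimate is 60000 nM, with a range of 25000 nM to 130000 nM.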

Compound 4, half-maximal inhibitory concentration: > 100000 nM
Compound 4 ended at the assay's limit; the forecaster's own chance of this, stated with the estimate: 45%; middle value at least 1.6-fold (0.22 log units) away from the limit.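

In this assay, acetyl in place of hydrogen on the aromatic nitrogen gives an at least 4.0-fold higher number from compound 2 to compound 4 (0.60 log units; beyond the scatter), so the loss does not depend on a ring on the carbonyl carbon; methyl there is enough. The steps among compound 1, compound 3 and compound 4 cannot be read, as each joins two limits. Values for this position now gather at one ceiling: the limit of > 100000 nM in this assay, at which 3 of the 4 values shown sit.

On these data alone, how far compound 1, compound 3 and compound 4 lie beyond that limit stays open. As far as these compounds go, it is also open whether an ethyl or benzyl group on the aromatic nitrogen, with no carbonyl, would stay close to compound 2.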